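Swapping the aryl halides for methyls on the hydrazone

The source may report more compounds than this note shows. Statements on the series, on what has been measured and on what is new or still open speak of the compounds shown alone.

Of the compounds shown here, three sharing one core have been tested in a functional assay on HT-29 cells (Homo sapiens) for cytotoxicity, read by MTT assay, with a stated time of 72 h; a lower number here means a stronger inhibitor, a higher number a weaker inhibitor. Compound 1 `CN(C)CCn1cnnc1-c1cc(Oc2ccc(NC(=O)N/N=C/c3ccc(Cl)cc3Cl)cc2F)ccn1` gives 390 nM, compound 2 `COc1ccc(/C=N/NC(=O)Nc2ccc(Oc3ccnc(-c4nncn4CCN(C)C)c3)c(F)c2)c(OC)c1` gives 1780 nM, and compound 3 `CN(C)CCn1cnnc1-c1cc(Oc2ccc(NC(=O)N/N=C/c3cc(Br)c(O)c(Br)c3)cc2F)ccn1` gives 2670 nM. Compound 3 therefore stands at the highest number of the three: the step of a 6.8-fold higher number from compound 1 to compound 3 (0.84 log units; beyond the scatter) lies beyond the scatter, whereas the step of a 1.5-fold higher number from compound 2 to compound 3 (0.18 log units; within the scatter) does not, so compound 2 and compound 3 cannot be ranked against each other.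

Within the data shown here, compound 4 `Cc1cc(/C=N/NC(=O)Nc2ccc(Oc3ccnc(-c4nncn4CCN(C)C)c3)c(F)c2)cc(C)c1O` is the next compound. 4-hydroxy-3,5-dimethylphenyl in place of 3,5-dibromo-4-hydroxyphenyl on a carbon with a double bond to nitrogen The steps that bear on this change are those that altered the same aryl group: a 4.6-fold higher number from compound 1 to compound 2 (0.66 log units; beyond the scatter) and a 6.8-fold higher number from compound 1 to compound 3 (0.84 log units; beyond the scatter). Among the measured compounds shown here, no measured step involves a methyl-bearing aryl group, so there is no direct precedent. The two variations away from compound 1 both weakened the compounds, and compound 2 and compound 3 sit close together; compound 4 is expected to fall near them, with a step of a 1.3-fold lower number from compound 3 to compound 4 (0.13 log units; within the scatter) that is expected to stay within the scatter. Compound 4 is estimated at 2000 nM, in a range from 700 nM to 6000 nM.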

Compound 4, half-maximal inhibitory concentration: 1220 nM
Estimate against measurement, compound 4: 1.6-fold (0.21 log units) above; low and high end bracket the measured number.
By their numbers in this assay, from the lowest: compound 1; then compounds 4, 2 and 3 (each within the scatter of the next, the first and the last beyond it).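

In this assay, among these compounds, 4-hydroxy-3,5-dimethylphenyl in place of 3,5-dibromo-4-hydroxyphenyl gives the first step at this position that lowers the number beyond the scatter (a 2.2-fold lower number from compound 3 to compound 4 (0.34 log units; beyond the scatter)), so with the hydroxy group kept, the two bromine atoms and the two methyl groups can be told apart here. The new group cannot be separated from 2,4-dimethoxyphenyl (a 1.5-fold lower number from compound 2 to compound 4 (0.16 log units; within the scatter)), yet it still falls short of 2,4-dichlorophenyl (a 3.1-fold higher number from compound 1 to compound 4 (0.50 log units; beyond the scatter)), which keeps compound 1 ahead of the other three compounds. Nothing given here accounts for these differences.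

The compounds shown do not say what the hydroxy group contributes, since 3,5-dimethylphenyl or an amine in its place does not appear among them. Nor do they say whether the lead of compound 1 depends on both chlorine atoms, which a monochlorophenyl group would test.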